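A few compounds are considered here, and "the series" means these few. Any claim that something is new, unique, unknown or untested is made for them only; others in the source may bear on it.

Among the compounds with values here, in a functional assay on CWR22R cells (Homo sapiens) for antiproliferative activity, read by MTT assay, with a stated time of 3 days (a lower number here means a stronger inhibitor, a higher number a weaker inhibitor), three compounds built on a shared core have numbers so far. Compound 1 `CCCS(=O)(=O)Nc1ccc(-c2cc(=O)c3c(O)cc(OC)c(OC(C)C)c3o2)cc1` gives 2900 nM, compound 2 `C=CC(=O)Nc1ccc(-c2cc(=O)c3c(O)cc(OC)c(OC(C)C)c3o2)cc1` gives 5800 nM, and compound 3 `COc1cc(O)c2c(=O)cc(-c3ccc(N4CC(C)NC(C)C4)cc3)oc2c1OCCO` gives 4500 nM. The value of compound 3 lies within the scatter of both other values, so these numbers do not rank it against either compound.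

Compound 4 `COc1cc(O)c2c(=O)cc(-c3ccc(N4CC(C)NC(C)C4)cc3)oc2c1OCC(OC)OC` has not yet been measured. It differs from compound 3 in one place: dimethoxymethyl in place of hydroxymethyl on a saturated chain carbon bound to an oxygen on an aromatic ring. Here, dimethoxymethyl stands in place of hydroxymethyl on a saturated chain carbon bound to an oxygen on an aromatic ring, turning 2-hydroxyethoxy into 2,2-dimethoxyethoxy.

Within the data shown here, the only measured step is a 2.0-fold higher number from compound 1 to compound 2 (0.30 log units; within the scatter), with vinylcarbonyl in place of propylsulfonyl on a nitrogen on an aromatic ring. That step lies within the scatter and concerns a different place, so it bears on this change only weakly. Among the measured compounds shown here, no measured step tests the group that changes here, and the data give no direction. The anchor is therefore compound 3 at 4500 nM, and no step beyond the scatter is expected in this assay. The estimated step is a 1.1-fold lower number from compound 3 to compound 4 (0.05 log units; within the scatter). For compound 4 the expected value is 4000 nM, with an estimated range from 1600 nM to 10000 nM.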

Compound 4, half-maximal inhibitory concentration: 5700 nM
Estimate against measurement, compound 4: 1.4-fold (0.15 log units) below, within the range that was stated.
By their numbers in this assay, from the lowest: compounds 1, 3, 4 and 2 (each within the scatter of the next).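

In this assay the step of a 1.3-fold higher number from compound 3 to compound 4 (0.10 log units; within the scatter) lies within the scatter, so these numbers do not separate dimethoxymethyl from hydroxymethyl on a saturated chain carbon bound to an oxygen on an aromatic ring. This pair gives the only step shown at this place, and it shows that 2-hydroxyethoxy can become 2,2-dimethoxyethoxy, with 5 heavy atoms entering for 2 and 0 hydrogen-bond donors for 1, without a step beyond the scatter in this assay. No measurement shown here offers an explanation for the size of this step.

Whether an amine, a carboxylic acid or a longer chain at this place would give a step beyond the scatter remains open, since the compounds shown carry only hydroxymethyl and dimethoxymethyl on this chain carbon. Also open is whether the same exchange would read the same way in a compound bearing the propylsulfonyl or vinylcarbonyl group of compound 1 or compound 2, as no pair shown tests it there.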